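The compounds below may be only part of what the source reports. "The series", "measured", "known", "first", "only" and "open" are said of these compounds alone.

Measured so far, in a functional assay on HEK293 cells for agonist activity at G-protein coupled receptor 84 (Homo sapiens), read by calcium flux; on this read-out lower numbers stand for an effect already at smaller amounts and higher numbers for an effect only at larger amounts of compound:

compound 1, `CCCCCCCc1nc(O)cc(O)n1` — 12.7 nM
compound 2, `CCCCCCCCc1cc(O)cc(O)n1` — 1.34 nM
compound 3, `CCCCCCCCc1nc(O)cc(O)n1` — 11.4 nM

Compound 2 stands lowest of the three numbers; compound 3 and compound 1 sit well beyond the scatter from it. The difference between the core of compound 2 and the core of compound 3 is not broken down here. Between compound 3 and compound 1 the change is hydrogen in place of methyl on a saturated chain carbon, seven bonds along the chain from an aromatic carbon and it gave a 1.1-fold higher number from compound 3 to compound 1 (0.05 log units; within the scatter).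

Compound 4, `CCCCCCCc1cc(O)cc(O)n1`, is still to be measured in this assay. It carries the same change on the core of compound 2: hydrogen in place of methyl on a saturated chain carbon, seven bonds along the chain from an aromatic carbon. Because compound 3 to compound 1 gave a 1.1-fold higher number from compound 3 to compound 1 (0.05 log units; within the scatter), the step from compound 2 to compound 4 is expected to be of similar size, a 1.1-fold higher number from compound 2 to compound 4 (0.05 log units; within the scatter). For compound 4 the expected value is 1.5 nM, estimated to lie between 0.7 nM and 3.5 nM.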

Compound 4, half-maximal effective concentration: 1.26 nM
Beside the measured number, compound 4's estimate is 1.2-fold (0.08 log units) above it; low and high end bracket the measured number.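

In this assay, hydrogen in place of methyl on a saturated chain carbon, seven bonds along the chain from an aromatic carbon, gives a 1.1-fold lower number from compound 2 to compound 4 (0.03 log units; within the scatter). On these two cores the change carries over with no measurable difference between the steps: the same change on two cores in this assay, a 1.1-fold higher number (0.05 log units; within the scatter) from compound 3 to compound 1 and a 1.1-fold lower number (0.03 log units; within the scatter) from compound 2 to compound 4, 1.2-fold (0.07 log units) apart, within the scatter of two such steps. Among the compounds shown here, both steps are within the scatter, so this shows only that the change leaves the number in place on both cores; it does not show how a change with a larger step would carry over, or how this one behaves on any other core.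

Still open, from the compounds shown here alone, is whether a longer chain or a butyl chain would behave the same way on either core. Also open, going by these compounds, is what an amine or a carboxylic acid at the chain end would do.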